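A few compounds are considered here, and "the series" means these few. Any claim that something is new, unique, unknown or untested is made for them only; others in the source may bear on it.

Measured so far in a functional assay (B cells) with Mus musculus as the target; a lower number here means that less compound is needed, a higher number that more compound is needed for the effect:
compound 1, `Nc1nc(O)c2c(n1)n(C1OC(CO)[C@@H](O)[C@H]1O)c(=O)n2C/C=C/c1ccccc1`, gives 103 uM;
compound 2, `CCOC(=O)Cn1c(=O)n(C2OC(CO)[C@@H](O)[C@H]2O)c2nc(N)nc(O)c21`, gives 48 uM;
compound 3, `CCn1c(=O)n(C2OC(CO)[C@@H](O)[C@H]2O)c2nc(N)nc(O)c21`, gives 15 uM.

Compound 3 has the lowest of the three numbers, with a 3.2-fold lower number from compound 2 to compound 3 (0.51 log units; beyond the scatter) and a 6.9-fold lower number from compound 1 to compound 3 (0.84 log units; beyond the scatter) both beyond the scatter. Compound 4, `N#Cc1ccc(Cn2c(=O)n(C3OC(CO)[C@@H](O)[C@H]3O)c3nc(N)nc(O)c32)cc1`, differs from compound 3 in one place: 4-cyanophenyl in place of methyl on a saturated chain carbon bound to an aromatic nitrogen. The two steps that bear on this both replace a larger group at that position with methyl and both lower the number; the change to compound 4 goes the other way, putting an aromatic ring back where compound 1 carried 2-phenylethenyl. A higher number is therefore expected for compound 4, of a size like a 3.7-fold higher number from compound 3 to compound 4 (0.56 log units; beyond the scatter). Compound 4 is expected to give about 55 uM in this assay, most likely between 20 uM and 150 uM.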

Compound 4, concentration for half-maximal effect: 15 uM
Beside the measured number, compound 4's estimate is 3.7-fold (0.56 log units) above it, and the stated range ends above it.
By their numbers in this assay, from the lowest: compounds 3 and 4 (each within the scatter of the next); then compound 2; then compound 1.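

The result of putting 4-cyanophenyl in place of methyl is no change at the digits printed from compound 3 to compound 4 (within the scatter) in this assay and so a large aromatic group can sit on this chain carbon without raising the number. Replacing ethoxycarbonyl gives a 3.2-fold lower number from compound 2 to compound 4 (0.51 log units; beyond the scatter) and replacing 2-phenylethenyl gives a 6.9-fold lower number from compound 1 to compound 4 (0.84 log units; beyond the scatter) so compound 4 goes against the earlier impression that a larger group means a higher number. No measurement here explains this behaviour. Still open, as far as these compounds go, is whether the nitrile matters, which a plain benzyl group would test, and how an amine or a carboxylic acid on this chain would read.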